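Enone reversal on the shared core: expectation for compound 4

This account rests on a few compounds, and the source may have more. Where it says the series, first, only, none or still open, it means among the compounds named here.

Compound 1 `COc1ccc(/C=C/C(=O)c2cc(-c3ccc(OC)c(OC)c3)n3nc(-c4ccccc4)cc3n2)cc1`, compound 2 `COc1ccc(-c2cc(/C=C/C(=O)c3ccc(C)c(C)c3)nc3cc(-c4ccccc4)nn23)cc1OC` and compound 3 `COc1cc(-c2cc(/C=C/C(=O)c3ccc(C)c(C)c3)nc3cc(-c4ccccc4)nn23)cc(OC)c1OC` have been run in a functional assay on DU-145 cells (Homo sapiens) for antiproliferative activity, read by MTT assay, with a stated time of 24 h; on this read-out lower numbers stand for stronger inhibition and higher numbers for weaker inhibition. Compound 1 gives 14900 nM, compound 2 gives 12100 nM and compound 3 gives 15400 nM. The change (2-(4-methoxyphenyl)ethenyl)carbonyl in place of 2-((3,4-dimethylphenyl)carbonyl)ethenyl on an aromatic carbon brought a 1.2-fold higher number from compound 2 to compound 1 (0.09 log units; within the scatter). The cores of compound 2 and compound 3 differ by methoxy in place of hydrogen on an aromatic carbon, and that brought a 1.3-fold higher number from compound 2 to compound 3 (0.10 log units; within the scatter). All three values sit within the scatter of one another.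

Compound 4 `COc1ccc(/C=C/C(=O)c2cc(-c3cc(OC)c(OC)c(OC)c3)n3nc(-c4ccccc4)cc3n2)cc1` carries the change ((2-(4-methoxyphenyl)ethenyl)carbonyl in place of 2-((3,4-dimethylphenyl)carbonyl)ethenyl on an aromatic carbon). Its place reads meta to a 3,4,5-trimethoxyphenyl group where the earlier place read meta to a 3,4-dimethoxyphenyl group, so it is the same kind of change, not the same. A step of a 1.1-fold higher number from compound 3 to compound 4 (0.06 log units; within the scatter) is expected from compound 3 to compound 4, set beside a 1.2-fold higher number from compound 2 to compound 1 (0.09 log units; within the scatter), because a 1.2-fold higher number from compound 2 to compound 1 (0.09 log units; within the scatter) stayed within the scatter. Compound 4 is accordingly estimated at 17500 nM, with a range from 9000 nM to 35000 nM.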

Compound 4, half-maximal inhibitory concentration: 16900 nM
Compound 4: middle estimate off by 1.0-fold (0.02 log units), on the high side; measured number inside the range.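

In this assay, (2-(4-methoxyphenyl)ethenyl)carbonyl in place of 2-((3,4-dimethylphenyl)carbonyl)ethenyl gives a 1.1-fold higher number from compound 3 to compound 4 (0.04 log units; within the scatter), and this agrees with the earlier step on the other core: the same change on two cores in this assay, a 1.2-fold higher number (0.09 log units; within the scatter) from compound 2 to compound 1 and a 1.1-fold higher number (0.04 log units; within the scatter) from compound 3 to compound 4, 1.1-fold (0.05 log units) apart, within the scatter of two such steps. The added methoxy gives a 1.1-fold higher number from compound 1 to compound 4 (0.05 log units; within the scatter), and it too agrees with its earlier counterpart: the same change on two cores in this assay, a 1.3-fold higher number (0.10 log units; within the scatter) from compound 2 to compound 3 and a 1.1-fold higher number (0.05 log units; within the scatter) from compound 1 to compound 4, 1.1-fold (0.05 log units) apart, within the scatter of two such steps. Both changes therefore carry between these cores without a step beyond the scatter, but since all four steps lie within the scatter, this does not show how a change with a step beyond the scatter would carry from one core to another.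

Still open, going by these compounds, is whether an amine or a carboxylic acid in place of a methoxy group on the 3,4,5-trimethoxyphenyl group would give a step beyond the scatter on the shared core.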